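The compounds below may be only part of what the source reports. "The series", "measured", "known", "first", "only" and "open" are said of these compounds alone.

Measured in a functional assay on K562 cells (Homo sapiens) for cytotoxicity, read by MTT assay, with a stated time of 48 h; on this read-out lower numbers stand for stronger inhibition and higher numbers for weaker inhibition:
- Compound 1 `CCOC(=O)[C@]1(C(=O)Nc2ccccc2)C[C@@H]1c1cc(OC)c(OC)c(OC)c1`: > 100000 nM (a limit of the assay)
- Compound 2 `CCOC(=O)[C@@]1(C(=O)NCc2ccc(C)cc2)C[C@H]1c1cc(OC)c(OC)c(OC)c1`: > 100000 nM (a limit of the assay)
- Compound 3 `CCOC(=O)[C@]1(C(=O)Nc2ccccc2Cl)C[C@@H]1c1cc(OC)c(OC)c(OC)c1`: 19500 nM

Compound 3 is the only one of these with an actual number, 19500 nM. The other two stand at the limit of > 100000 nM in this assay, at which 2 of the 3 values shown sit.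

Compound 4 `CCOC(=O)[C@@]1(C(=O)Nc2ccccc2Cl)C[C@H]1c1cc(OC)c(OC)c(OC)c1` is the mirror image of compound 3: the two compounds have the same atoms and bonds and differ only in configuration as drawn: 2 of 2 stereo elements differ (all stereocentres are inverted: mirror images); a stereocentre at a saturated ring carbon is drawn R in compound 3 and S in compound 4; a stereocentre at a saturated ring carbon is drawn R in compound 3 and S in compound 4. For the measured compounds named here, the only measured step is an at least 5.1-fold lower number from compound 1 to compound 3 (0.70 log units; beyond the scatter), where chloro takes the place of hydrogen on an aromatic carbon. Compound 4 keeps that chloro, but this step involves no change of configuration, so it gives no direction for the inversion. In this assay, going by the values given here, a change no larger than that step is therefore expected, with a slight lean towards weaker inhibition. The expected change is a 1.5-fold higher number from compound 3 to compound 4 (0.19 log units; within the scatter), and no shift clearly beyond the scatter is predicted. For compound 4 the estimated value is 30000 nM, with an expected range of 7000 nM to 100000 nM.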

Compound 4, half-maximal inhibitory concentration: > 100000 nM
Compound 4 gave a limit, no number; the forecaster's own chance of this, stated with the estimate: 30%; middle value at least 3.3-fold (0.52 log units) from the limit.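

In this assay, for the compounds shown here, inverting both stereocentres gives an at least 5.1-fold higher number from compound 3 to compound 4 (0.70 log units; beyond the scatter), so this series responds to configuration as well as to the aromatic substituent, the only kind of change the earlier step covered. Compound 4 gives no number, only a limit of the assay, > 100000 nM, and so it joins the compounds that reach no measurable value: the limit of > 100000 nM in this assay, at which 3 of the 4 values shown sit. The measurable value of compound 3 therefore depends on its configuration as drawn, with no change in atoms or bonds: the fact that compounds 3 and 4 differ only in the configuration as drawn

The step from compound 2 to compound 4 cannot be read, since both values are limits. The compounds shown leave open whether a bromo or a methoxy group in place of the chloro would strengthen or weaken inhibition in the configuration of compound 3.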